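Oxadiazole for Imidazole on Two Benzamide Isomers

A few compounds are considered here, and "the series" means these few. Any claim that something is new, unique, unknown or untested is made for them only; others in the source may bear on it.

Measured compounds:
compound 1, `CCCN(CC[C@H]1CC[C@H](NC(=O)c2ccc(-n3ccnc3)cc2)CC1)[C@H]1CCc2nc(N)sc2C1`: 1.9 nM
compound 2, `CCCN(CC[C@H]1CC[C@H](NC(=O)c2cccc(-n3ccnc3)c2)CC1)[C@H]1CCc2nc(N)sc2C1`: 1.1 nM
compound 3, `CCCN(CC[C@H]1CC[C@H](NC(=O)c2ccc(-c3noc(CC)n3)cc2)CC1)[C@H]1CCc2nc(N)sc2C1`: 2.1 nM

These three values come from an assay on brain for displacement of a labelled ligand from D(3) dopamine receptor (Rattus norvegicus); on this read-out lower numbers stand for stronger inhibition and higher numbers for weaker inhibition. All three compounds share one core and differ only in the aryl group on the carbonyl carbon. Compound 2 differs from compound 1 by 3-(1H-imidazol-1-yl)phenyl in place of 4-(1H-imidazol-1-yl)phenyl on a carbonyl carbon, which gave a 1.7-fold lower number from compound 1 to compound 2 (0.24 log units; within the scatter). Compound 3 differs from compound 1 by 5-ethyl-1,2,4-oxadiazol-3-yl in place of 1H-imidazol-1-yl on an aromatic carbon, and that change gave a 1.1-fold higher number from compound 1 to compound 3 (0.04 log units; within the scatter).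

Compound 4, `CCCN(CC[C@H]1CC[C@H](NC(=O)c2cccc(-c3noc(CC)n3)c2)CC1)[C@H]1CCc2nc(N)sc2C1`, is not yet measured in this assay. It differs from compound 2 by 5-ethyl-1,2,4-oxadiazol-3-yl in place of 1H-imidazol-1-yl on an aromatic carbon. Within the data shown here, this is the same kind of change as the one from compound 1 to compound 3, but the place is not identical: in compound 3 the entering group sits para to a large group, whereas in compound 4 it sits meta to a large group. Because the earlier step was a 1.1-fold higher number from compound 1 to compound 3 (0.04 log units; within the scatter), compound 4 is expected to show a 1.2-fold higher number from compound 2 to compound 4 (0.07 log units; within the scatter). Compound 4 is therefore estimated at 1.3 nM, with an expected range from 0.55 nM to 3.2 nM.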

Compound 4, inhibition constant: 1.5 nM
Compound 4: the middle estimate sits 1.2-fold (0.06 log units) below what was measured; low and high end bracket the measured number.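

In this assay, placing 5-ethyl-1,2,4-oxadiazol-3-yl in place of 1H-imidazol-1-yl on the second benzamide isomer, meta to a large group, gave a 1.4-fold higher number from compound 2 to compound 4 (0.13 log units; within the scatter). Set beside the earlier case, where the entering group sits para to a large group, the change carried over from one core to the other without a difference that stands clear of the scatter: the same change on two cores in this assay, a 1.1-fold higher number (0.04 log units; within the scatter) from compound 1 to compound 3 and a 1.4-fold higher number (0.13 log units; within the scatter) from compound 2 to compound 4, 1.2-fold (0.09 log units) apart, within the scatter of two such steps This shows that the exchange left the number within the scatter at both places, but it rests on only two pairs and does not establish a real shift in either direction, nor that the same would hold on any other core in the series.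

The compounds shown leave open whether a longer chain in place of the ethyl on the oxadiazole would stay within the same range. They also leave open whether an amine or a carboxylic acid on that ring would do so.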